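A few compounds are considered here, and "the series" means these few. Any claim that something is new, unique, unknown or untested is made for them only; others in the source may bear on it.

Measured compounds in a functional assay on SNB-75 cells (Homo sapiens) for inhibition, read by sulforhodamine B assay, with a stated time of 48 h; on this read-out lower numbers stand for higher toxicity in this test and higher numbers for lower toxicity in this test. Compound 1 `COc1cc(-c2nn(-c3cccc(NC(=O)Nc4ccc(Cl)c(Cl)c4)c3)cc2-c2ccncc2)ccc1Cl` gives > 50000 nM, a limit of the assay. Compound 2 `COc1cc(-c2nn(-c3cccc(NC(=O)c4ccc(Cl)c(C(F)(F)F)c4)c3)cc2-c2ccncc2)ccc1Cl` gives > 32500 nM, again a limit. Compound 3 `O=C(Nc1cccc(-n2cc(-c3ccncc3)c(-c3ccc(Cl)c(O)c3)n2)c1)Nc1cc(C(F)(F)F)cc(C(F)(F)F)c1` gives 7030 nM.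

Compound 2 thus stands at the limit of > 32500 nM in this assay, at which 1 of the 3 values shown sits, and compound 1 at the limit of > 50000 nM in this assay, at which 1 of the 3 values shown sits; the step that the two limits leave unreadable from compound 1 to compound 2 cannot be read. Within the data shown here, compound 3 differs from compound 2 in more than one place, so no step is drawn between them.

Compound 4 `COc1cc(-c2nn(-c3cccc(NC(=O)c4ccccc4)c3)cc2-c2ccncc2)ccc1Cl` carries phenyl in place of 4-chloro-3-(trifluoromethyl)phenyl on a carbonyl carbon. Among the measured compounds shown here, no measured step bears on this change, and the only readable comparison involves a different amide partner and a changed core, so nothing fixes a direction. Compound 4 is expected to sit near the limit again, estimated at 40000 nM (range 8000 nM to 100000 nM), the step that the limit leaves unreadable from compound 2 to compound 4 being expected within scatter.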

Compound 4, concentration lethal to 50% of the cells: > 100000 nM
Compound 4: only a limit was reported; the forecaster's own chance of this, stated with the estimate: 65%; middle value at least 2.5-fold (0.39 log units) from the limit.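

Compound 4 gives > 100000 nM, a limit of the assay. Among these compounds, compound 1, compound 2 and compound 4 all stand at limits, so no step among them can be read. On these data alone, whether phenyl in place of 4-chloro-3-(trifluoromethyl)phenyl changes the read-out at all remains open.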